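Allyl for butyl on the ring nitrogen: outlook for compound 4

The source may report more compounds than this note shows. Statements on the series, on what has been measured and on what is new or still open speak of the compounds shown alone.

Three compounds of this series have been run in a functional assay on aorta with Alpha-1D adrenergic receptor (Rattus norvegicus) as the target; on this read-out lower numbers stand for an effect already at smaller amounts and higher numbers for an effect only at larger amounts of compound. Going by the values given here, compound 2 `CCCCn1nc(Cc2ccc(OC)c(OC)c2)c2ccccc2c1=O` gives 5400 nM, the only number so far. Compound 1 `CCCCn1nc(Cc2ccc(SC)cc2)c2ccccc2c1=O` shows only a limit, > 100000 nM. Compound 3 `CCCCn1nc(Cc2ccc(Cl)cc2)c2ccccc2c1=O` likewise shows only a limit, > 100000 nM. The step that the two limits leave unreadable from compound 1 to compound 3 stays unreadable because of the limit of > 100000 nM in this assay, at which 2 of the 3 values shown sit. Compound 4 `C=CCn1nc(Cc2ccc(OC)c(OC)c2)c2ccccc2c1=O` keeps the rest of compound 2 and differs only in vinyl in place of propyl on a saturated chain carbon bound to an aromatic nitrogen. Among the compounds with values here, no measured step touches this chain, so the expectation rests on compound 2 alone. Compound 4 is expected to land close to compound 2, the step of a 1.1-fold higher number from compound 2 to compound 4 (0.05 log units; within the scatter) being estimated as not beyond the usual scatter. The estimate for compound 4 in this assay is 6000 nM, with a range from 2000 nM to 18000 nM.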

Compound 4, half-maximal effective concentration: 9800 nM
For compound 4 the middle estimate is 1.6-fold (0.21 log units) below the measured one; the range from low to high includes it.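

In this assay, the series now has a readable step on the chain at this place, on a saturated chain carbon bound to an aromatic nitrogen: vinyl in place of propyl gives a 1.8-fold higher number from compound 2 to compound 4 (0.26 log units; within the scatter). Butyl and allyl thus stand within the scatter of each other here, so the added double bond leaves no readable mark on this read-out. The compounds shown give no cause for this step. Open, from the compounds shown here alone, is how a longer chain or an amine at this place would read. Also open is whether allyl on the core of compound 1 or compound 3, both shown only as limits, would give a number.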